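From Pyrimidin-2-yl to Furan-3-yl: an Expected Shift

A few compounds are considered here, and "the series" means these few. Any claim that something is new, unique, unknown or untested is made for them only; others in the source may bear on it.

Measured so far:
compound 1 `Cc1ccnc(-c2ccccc2OCC2=NCCN2)c1`, in a functional assay for activation of Alpha-1A adrenergic receptor (Homo sapiens), read by calcium flux (a lower number here means that less compound is needed, a higher number that more compound is needed for the effect), compound 1 gives < 100000 nM, a limit of the assay and not a number.
compound 2 `Cc1cccc(-c2ccccc2OCC2=NCCN2)n1`, in this assay compound 2 gives 126 nM.
compound 3 `c1cnc(-c2ccccc2OCC2=NCCN2)nc1`, in this assay compound 3 gives 1260 nM.

Compound 3 stands at the highest of the two numbers, with compound 2 the nearest neighbour and a gap between them that lies beyond the usual scatter. Compound 1 sits at the limit (the limit of < 100000 nM in this assay, at which 1 of the 3 values shown sits), so no number exists for it.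

Compound 4 `c1ccc(-c2ccoc2)c(OCC2=NCCN2)c1` is not yet measured. It differs from compound 3 in one place: furan-3-yl in place of pyrimidin-2-yl on an aromatic carbon. No step between measured compounds matches this change, so nothing in the shown numbers fixes its size. Compounds 2 and 3 show that a six-membered aromatic ring with 2 hetero atoms gives a higher number than one with a single nitrogen and a methyl, but this is two compounds only, and compound 1 shows that a methyl on such a ring can also push the value to the limit.

For compound 4 the expected step from compound 3 is a 3.2-fold lower number from compound 3 to compound 4 (0.50 log units; beyond the scatter), a modest move toward a lower number. The estimate for compound 4 in this assay is 400 nM, with a range from 60 nM to 3000 nM.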

Compound 4, half-maximal effective concentration: 0.501 nM
Compound 4: middle estimate off by 800-fold (2.90 log units), on the high side; the whole stated range lies above it.
By their numbers in this assay, from the lowest: compound 4; then compound 2; then compound 3.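

In this assay, furan-3-yl in place of pyrimidin-2-yl on an aromatic carbon, ortho to a group of 7 heavy atoms, gives a 2500-fold lower number from compound 3 to compound 4 (3.40 log units; beyond the scatter), which shows that this position responds very strongly to the ring it carries. The earlier compounds shown here held only six-membered aromatic rings here, whereas compound 4 brings a five-membered aromatic ring with 1 hetero atom, an oxygen, and with it compound 4 reaches 0.501 nM in this read-out, so a ring without nitrogen is no obstacle at this place. The change alters ring size, the kind of hetero atom and their count all at once, and this single step does not separate them.

The compounds shown leave open whether thiophen-3-yl, furan-2-yl or plain phenyl at the same place would give a number as low as that of compound 4, and what a methyl or an amine on the furan ring would do. Nothing in the data shown bears on why this step is so large.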